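This account rests on a few compounds, and the source may have more. Where it says the series, first, only, none or still open, it means among the compounds named here.

Of the compounds shown here, three have been measured in an assay on isolated protein for inhibition of MAP kinase-activated protein kinase 5 (Homo sapiens), read by mobility shift assay, tested at 30 uM; on this read-out higher numbers stand for more inhibition at the one concentration tested (going by the name of the read-out) and lower numbers for less inhibition. Compound 1 `COc1ccc(-c2c(C)[nH]c(=O)c3c(N)nn(C)c23)cc1` gives 13%. Compound 2 `Cc1cc2c(c(N)nn2C)c(N2CCCCC2)n1` gives 17%. Compound 3 `CC(C)(C)c1cc2nn(-c3ccccc3)c(N)c2c(=O)[nH]1` gives 2%, the lowest of the three numbers; compound 1 stands higher by a margin beyond the scatter, and compound 2 stands higher still, also beyond the scatter. Going by the values given here, no pair among the measured compounds differs in a single place, so no measured step is available to gauge the weight of any one change.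

Compound 4 `COc1ccccc1-c1cc2nn(-c3ccccc3)c(N)c2c(=O)[nH]1` is not yet measured. It differs from compound 3 in one place: 2-methoxyphenyl in place of tert-butyl on an aromatic carbon. The only hint about a methoxyphenyl group in this series comes from compound 1, which carries one and gives 13%. The expected step in this assay is a number 6 percentage points higher from compound 3 to compound 4 (within the scatter), a modest rise rather than a large one. For compound 4 the estimate is 8%, with a range from 0% to 22%.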

Compound 4, a percentage reported as inhibition, at one concentration (the size of the read-out at that concentration, not a potency): 6%
For compound 4 the middle estimate is 2 percentage points above the measured one; measured number inside the range.
By their numbers in this assay, from the lowest: compounds 3, 4, 1 and 2 (each within the scatter of the next, the first and the last beyond it).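

Working from the first single-place step in the series, this assay reads a number 4 percentage points higher from compound 3 to compound 4 (within the scatter) for 2-methoxyphenyl in place of tert-butyl on the aromatic carbon next to the ring nitrogen. At this position, the larger group with its own aromatic ring and one hydrogen-bond acceptor is therefore not separated from tert-butyl by this read-out. No available measurement explains this result.

As far as these compounds go, whether a basic amine such as piperidine or a carboxylic acid at this carbon would move the read-out beyond the scatter remains open. Going by these compounds alone, also open is how much of the low numbers of compound 3 and compound 4 depends on the phenyl on the ring nitrogen, as no single-place step links either compound to compound 1 or compound 2.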